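From 3,4-dimethylphenyl to 4-(dimethylamino)phenyl on the shared core

This account rests on a few compounds, and the source may have more. Where it says the series, first, only, none or still open, it means among the compounds named here.

In a functional assay on MCF7 cells (Homo sapiens) for inhibition, read by CCK-8 assay, with a stated time of 48 h (on this read-out higher numbers stand for weaker inhibition and lower numbers for stronger inhibition), compound 2 (`COc1cc(-c2ccnc3cc(-c4cn(CO)c5ccccc45)nn23)cc(OC)c1OC`) gives 19 nM. Compound 3 (`COc1cc(-c2ccnc3cc(-c4ccc(C)c(C)c4)nn23)cc(OC)c1OC`) gives 26 nM, which lies within the scatter of the value of compound 2, so the two numbers cannot be told apart. Compound 1 (`COc1cc(-c2cc3nccc(-c4cc(OC)c(OC)c(OC)c4)n3n2)cc(OC)c1OC`) is recorded only as a limit, > 10000 nM, and not as a number.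

Compound 4 (`COc1cc(-c2ccnc3cc(-c4ccc(N(C)C)cc4)nn23)cc(OC)c1OC`) carries 4-(dimethylamino)phenyl in place of 3,4-dimethylphenyl on an aromatic carbon of a five-membered aromatic ring with 2 nitrogen: 4-(dimethylamino)phenyl in place of 3,4-dimethylphenyl on an aromatic carbon. The group that leaves and the group that enters both hold one six-membered aromatic ring of carbon only.

Among the measured compounds shown here, no measured pair isolates this change, so the expectation starts from compound 3 at 26 nM and carries wide margins. A small step toward weaker inhibition in this assay is expected, a 1.5-fold higher number from compound 3 to compound 4 (0.19 log units; within the scatter), and it may not clear the scatter. For compound 4 the estimated value is 40 nM, with an expected range from 10 nM to 200 nM.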

Compound 4, half-maximal inhibitory concentration: 44 nM
Compound 4: the middle estimate sits 1.1-fold (0.04 log units) below what was measured, and the stated range covers the measured number.
By their numbers in this assay, from the lowest: compounds 2, 3 and 4 (each within the scatter of the next, the first and the last beyond it). At a limit, above all of these: compound 1.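

In this assay, replacing 3,4-dimethylphenyl with 4-(dimethylamino)phenyl gives a 1.7-fold higher number from compound 3 to compound 4 (0.23 log units; within the scatter), so the two groups cannot be told apart at this aromatic carbon of the five-membered ring. This is the first pair shown that isolates a change at this position, and in this pair the position takes an entering group with a nitrogen and a hydrogen-bond acceptor without a step beyond the scatter. Nothing measured here bears on the reason for this step.

The compounds shown leave open how a carboxylic acid or a morpholine on the phenyl ring would read at this position, and whether dimethylamino holds up at another place on that ring. Also open, on these data alone, is whether a six-membered aromatic ring is needed here at all, which a cyclohexyl group in its place would test.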